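Swapping a small selenium group for a longer chain

This account rests on a few compounds, and the source may have more. Where it says the series, first, only, none or still open, it means among the compounds named here.

- compound 1 `COc1ccc(N(C)c2nc(C)nc3ccccc23)cc1C(=O)OCC[Se]C#N`: 2960 nM
- compound 2 `COc1ccc(N(C)c2nc(C)nc3ccccc23)cc1[Se]C`: 3 nM

Both numbers come from a functional assay on LoVo cells (Homo sapiens) for inhibition, read by MTT assay, with a stated time of 48 h; on this read-out higher numbers stand for weaker inhibition and lower numbers for stronger inhibition. Compound 2 holds the lower of the two numbers, which makes it the stronger inhibitor of this pair. Among the measured compounds shown here, only one measured step bears on what follows: a 990-fold lower number from compound 1 to compound 2 (2.99 log units; beyond the scatter). That step is large.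

Compound 3 `COc1ccc(N(C)c2nc(C)nc3ccccc23)cc1OCCCC[Se]C#N` keeps the core of compound 2 and changes one place, an aromatic carbon of a six-membered aromatic ring of carbon only, ortho to a methoxy group. The change is a group of 8 heavy atoms (5 carbon, 1 nitrogen, 1 oxygen, 1 selenium; no ring) in place of a group of 2 heavy atoms (1 carbon, 1 selenium; no ring), on an aromatic carbon. It runs against the direction of the measured step, since a small group leaves and a larger one enters. For the measured compounds named here, the entering group differs from the one in compound 1, so that step is only a rough guide, and two measured compounds show no general pattern.

A large rise in this assay is expected, resting on compound 1 at 2960 nM, though perhaps not the whole distance. The estimated change is a 130-fold higher number from compound 2 to compound 3 (2.12 log units; beyond the scatter). For compound 3 the expected value is 400 nM, with an expected range of 40 nM to 3000 nM.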

Compound 3, half-maximal inhibitory concentration: 882 nM
Compound 3: the middle estimate sits 2.2-fold (0.34 log units) below what was measured; the range from low to high includes it.
By their numbers in this assay, from the lowest: compound 2; then compound 3; then compound 1.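

In this assay, a second long group at this aromatic carbon gives a 290-fold higher number from compound 2 to compound 3 (2.47 log units; beyond the scatter), so the small selenium group of compound 2 stays far ahead of both long groups shown, which each hold 8 heavy atoms. The two long groups are not equivalent, though: the chain of compound 3 has one oxygen and five carbons where that of compound 1 has two oxygens and four carbons, and the change gives a 3.4-fold lower number from compound 1 to compound 3 (0.53 log units; beyond the scatter), a modest step but one beyond the usual scatter, so equal heavy-atom counts do not guarantee equal numbers at this position. Nothing available here accounts for either step.

These three compounds do not separate the effect of chain length from that of the selenium-bound nitrile at the chain end, since both long groups carry that end and the small group carries neither. A shorter chain ending in the same selenium-bound nitrile, or a chain of similar length ending in an amine, would help pull those two features apart.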